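One Trifluoromethyl Fewer: Expected Effect on Cell Growth

This account rests on a few compounds, and the source may have more. Where it says the series, first, only, none or still open, it means among the compounds named here.

Of the compounds shown here, two sharing one core have so far been tested in a functional assay on U-251 cells (Homo sapiens) for inhibition, read by sulforhodamine B assay, with a stated time of 48 h, tested at 10 uM; a lower number here means a stronger effect, a higher number a weaker effect of the compound at the concentration tested. Compound 1 `O=C(Nc1cccc(-n2cc(-c3ccncc3)c(-c3cc(O)cc(Cl)c3)n2)c1)Nc1ccc(Cl)c(Cl)c1` gives -56.5%. Compound 2 `COc1cc(Cl)cc(-c2nn(-c3cccc(NC(=O)Nc4cc(C(F)(F)F)cc(C(F)(F)F)c4)c3)cc2-c2ccncc2)c1` gives -58%, the lower of the two numbers, yet so close to compound 1 that both values lie within the usual scatter of each other. Compound 3 `COc1cc(Cl)cc(-c2nn(-c3cccc(NC(=O)Nc4cccc(C(F)(F)F)c4)c3)cc2-c2ccncc2)c1` is not yet measured; it differs from compound 2 in a single place: hydrogen in place of trifluoromethyl on an aromatic carbon. Going by the values given here, no measured pair shows what this change does here, so only a small shift toward a higher number, hardly beyond the scatter, is expected. Compound 3 is estimated at -50%, between -75% and -20%, an expected step of a number 8 percentage points higher from compound 2 to compound 3 (within the scatter).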

Compound 3, a percentage reported as activity, at one concentration (the size of the read-out at that concentration, not a potency): 4.59%
The estimate for compound 3 lay 54.6 percentage points below the measured number; measured number above the stated range.
By their numbers in this assay, from the lowest: compounds 2 and 1 (each within the scatter of the next); then compound 3.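

In this assay, this one place on the ring turns out to matter greatly: hydrogen in place of trifluoromethyl gives a number 62.6 percentage points higher from compound 2 to compound 3 (beyond the scatter), a large change from a single edit, which the close values of the first two compounds could not reveal. Keeping the remaining trifluoromethyl group on that ring does not preserve the strong effect seen for compound 2. Nothing available explains why the step is so large. Still open, as far as these compounds go, is whether another group at this place, such as a nitrile or an amine, would restore the effect seen for compound 2.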